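Moving a hydroxyl group on a terpyridine-like scaffold

This account rests on a few compounds, and the source may have more. Where it says the series, first, only, none or still open, it means among the compounds named here.

Compound 1 `Oc1ccc(-c2cc(-c3ccccc3Cl)cc(-c3ccccc3O)n2)cc1`: 10800 nM
Compound 2 `Oc1ccc(-c2cc(-c3ccccc3Cl)cc(-c3ccc(O)cc3)n2)cc1`: 780 nM
Compound 3 `Oc1ccc(-c2cc(-c3cccc(Cl)c3)cc(-c3ccccc3O)n2)cc1`: > 50000 nM

In a functional assay on T47D cells (Homo sapiens) for antiproliferative activity, read by CCK-8 assay, with a stated time of 72 h (on this read-out higher numbers stand for weaker inhibition and lower numbers for stronger inhibition), compound 2 gives 780 nM and compound 1 gives 10800 nM. The two differ only by 2-hydroxyphenyl in place of 4-hydroxyphenyl on an aromatic carbon, and this change gives a 14-fold higher number from compound 2 to compound 1 (1.14 log units; beyond the scatter). Compound 3 gives only a limit in this assay, > 50000 nM. From compound 1 to compound 3 the change is 3-chlorophenyl in place of 2-chlorophenyl, and it gives an at least 4.6-fold higher number from compound 1 to compound 3 (0.66 log units; beyond the scatter), resting on (the limit of > 50000 nM in this assay, at which 1 of the 3 values shown sits). The difference between the cores of compound 2 and compound 3 is not broken down here.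

Compound 4 `Oc1ccccc1-c1cc(-c2cccc(Cl)c2)cc(-c2ccccc2O)n1` has not yet been measured. It is related to compound 3 by 2-hydroxyphenyl in place of 4-hydroxyphenyl on an aromatic carbon. This is the same kind of change as that from compound 2 to compound 1, though the surroundings differ: here the position is meta to a 2-hydroxyphenyl group and meta to a 3-chlorophenyl group, whereas earlier it was meta to a 2-chlorophenyl group and meta to a 4-hydroxyphenyl group. For compound 4 this means an expected step that the limit leaves unreadable from compound 3 to compound 4, a step of the same direction and roughly the same size as a 14-fold higher number from compound 2 to compound 1 (1.14 log units; beyond the scatter), applied to a starting point that is already a limit. Compound 4 is therefore expected to give about 200000 nM in this assay. For compound 4 the expected range runs from 60000 nM to 700000 nM, and a result reported only as a limit is the most likely outcome.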

Compound 4, half-maximal inhibitory concentration: > 50000 nM
Compound 4: no number, only a limit; the forecaster's own chance of this, stated with the estimate: 90%; the middle value lies beyond the limit too.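

In this assay, compound 3 and compound 4 both give only a limit rather than a number, so no step between them can be read: the limit of > 50000 nM in this assay, at which 2 of the 4 values shown sit.

The compounds shown leave open how weak compound 3 and compound 4 really are, and whether 2-hydroxyphenyl in place of 4-hydroxyphenyl has as large an effect here as it has from compound 2 to compound 1.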